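Nitrone series on PC-3 cells: tert-butyl for benzyl

A few compounds are considered here, and "the series" means these few. Any claim that something is new, unique, unknown or untested is made for them only; others in the source may bear on it.

Measured compounds:
- compound 1 `COc1ccc(-n2cc(/C=[N+](\[O-])Cc3ccccc3)nn2)cc1`: in a functional assay on PC-3 cells (Homo sapiens) for inhibition, read by MTT assay, with a stated time of 24 h (on this read-out higher numbers stand for weaker inhibition and lower numbers for stronger inhibition), compound 1 gives > 100000 nM, a limit of the assay.
- compound 2 `CCCCCCCCn1cc(/C=[N+](\[O-])Cc2ccccc2)nn1`: in this assay compound 2 gives > 100000 nM, a limit of the assay.
- compound 3 `CCCCCCCCCCn1cc(/C=[N+](\[O-])Cc2ccccc2)nn1`: in this assay compound 3 gives > 100000 nM, a limit of the assay.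

Compound 2 stands at the limit of > 100000 nM in this assay, at which 3 of the 3 values shown sit; its value is a limit and not a number. Among the compounds with values here, the one measured step, a step that the two limits leave unreadable from compound 2 to compound 3, is ethyl in place of hydrogen on a saturated chain carbon, eight bonds along the chain from an aromatic nitrogen, and both ends of it are limits, so its size cannot be read.

Compound 4 `CCCCCCCCn1cc(/C=[N+](\[O-])C(C)(C)C)nn1` differs from compound 2 by tert-butyl in place of benzyl on a double-bonded nitrogen, in words tert-butyl in place of benzyl on a double-bonded nitrogen. No measured step touches this position; the only step shown, from compound 2 to compound 3, is unreadable and lies elsewhere in the molecule. With every value shown sitting at the limit, the step of a number no higher from compound 2 to compound 4 (the limit leaves the size open) is expected to be none beyond the scatter, though a readable number is not ruled out. Compound 4 is therefore estimated at 100000 nM in this assay, in the range 30000 nM to 300000 nM, most likely reported again as a limit.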

Compound 4, half-maximal inhibitory concentration: 24600 nM
Beside the measured number, compound 4's estimate is 4.1-fold (0.61 log units) above it; the whole stated range lies above it.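

In this assay compound 4 gives 24600 nM, the only readable number among the compounds shown. Tert-butyl in place of benzyl on a double-bonded nitrogen gives an at least 4.0-fold lower number from compound 2 to compound 4 (0.60 log units; beyond the scatter), and one end of that step is a limit of the assay. The step along the chain cannot be read, so this nitrogen is the only place shown where a change registers on the read-out, against a series that otherwise sits at the limit: the limit of > 100000 nM in this assay, at which 3 of the 4 values shown sit.

Open, from the compounds shown here alone, is whether the step belongs to tert-butyl itself or to the loss of the benzyl ring, which a single pair cannot separate; isopropyl or cyclohexyl on the same nitrogen would bear on this. Also open, going by these compounds, is whether tert-butyl gives a readable number alongside the longer chain of compound 3 or the aromatic group of compound 1.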